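The source may report more compounds than this note shows. Statements on the series, on what has been measured and on what is new or still open speak of the compounds shown alone.

Of the compounds shown here, three built on one shared core have been tested in a functional assay on ACHN cells (Homo sapiens) for cytotoxicity, read by sulforhodamine B assay, with a stated time of 72 h; a higher number here means a weaker inhibitor of growth, a lower number a stronger inhibitor of growth. Compound 1 `CC(=O)N1c2ccccc2CCC1C(=O)Nc1ccccc1O` gives 50700 nM. Compound 2 `O=C(Nc1ccccc1O)C1CCc2ccccc2N1C(=O)c1ccc(Cl)cc1` gives 19600 nM, and compound 3 `CCCCCCCCC(=O)N1c2ccccc2CCC1C(=O)Nc1ccccc1O` gives 65000 nM. Compound 3 therefore carries the highest of the three numbers, although the gap to compound 1 is small: a 1.3-fold higher number from compound 1 to compound 3 (0.11 log units; within the scatter). The gap to compound 2 is larger: a 3.3-fold higher number from compound 2 to compound 3 (0.52 log units; beyond the scatter).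

Compound 4 `O=C(Nc1ccccc1O)C1CCc2ccccc2N1C(=O)c1cccc(Cl)c1` differs from compound 3 in one place: 3-chlorophenyl in place of octyl on a carbonyl carbon. Two of the measured steps bear on this change. The step from the aromatic ring to the open chain on the same carbonyl carbon raised the number, as a 3.3-fold higher number from compound 2 to compound 3 (0.52 log units; beyond the scatter) shows, and putting an aromatic ring in place of methyl at that carbonyl carbon lowered it, as a 2.6-fold lower number from compound 1 to compound 2 (0.41 log units; beyond the scatter) shows. Both point the same way: replacing the octyl chain by a chlorine-bearing aromatic ring is expected to give a modest lower number in this assay, beyond the scatter, roughly matching compound 2.

For compound 4 the expected value in this assay is 22000 nM, with a range from 8000 nM to 60000 nM. This expectation corresponds to the step of a 3.0-fold lower number from compound 3 to compound 4 (0.47 log units; beyond the scatter).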

Compound 4, concentration for 50% growth inhibition: 17200 nM
Estimate against measurement, compound 4: 1.3-fold (0.11 log units) above; low and high end bracket the measured number.
By their numbers in this assay, from the lowest: compounds 4 and 2 (each within the scatter of the next); then compounds 1 and 3 (each within the scatter of the next).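

In this assay, 3-chlorophenyl and 4-chlorophenyl on this carbonyl carbon cannot be told apart (a 1.1-fold lower number from compound 2 to compound 4 (0.06 log units; within the scatter)), so moving the chlorine between these two ring places produces no readable change. The lower number seen earlier with compound 2 is now repeated by a second chlorophenyl compound, against both the octyl chain (a 3.8-fold lower number from compound 3 to compound 4 (0.58 log units; beyond the scatter)) and the methyl group (a 2.9-fold lower number from compound 1 to compound 4 (0.47 log units; beyond the scatter)), and among these four compounds none goes against this pattern, although both steps remain modest. The data shown offer no independent measurement that could explain why the two chlorophenyl groups give lower numbers than the methyl and octyl groups.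

The compounds shown leave open whether the chlorine matters at all, since a plain phenyl group would be needed to separate the effect of the ring from that of the chlorine, and whether a methoxy group or a carboxylic acid on the same ring would give a similar number. They also leave open whether an amine-bearing chain on this carbonyl carbon would behave like the octyl chain or move the number further.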